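The source may report more compounds than this note shows. Statements on the series, on what has been measured and on what is new or still open speak of the compounds shown alone.

Working notes on the series. In an ADME assay on NIH3T3 cells (Mus musculus) for cytotoxicity, read by MTT assay, with a stated time of 24 h (on this read-out higher numbers stand for weaker inhibition and lower numbers for stronger inhibition), compound 1 (`O=C(CSc1nnc(-c2ccncc2)o1)N/N=C/c1cc(Cl)cc(Cl)c1O`) gives 171000 nM and compound 2 (`O=C(CSc1nnc(-c2ccncc2)o1)N/N=C/c1ccc(O)c(O)c1`) gives 154000 nM, so compound 2 stands level with compound 1 within the scatter. Compound 3 (`O=C(CSc1nnc(-c2ccncc2)o1)N/N=C/c1ccc(Cl)cc1Cl`) is not yet measured and departs from compound 2 by one change: 2,4-dichlorophenyl in place of 3,4-dihydroxyphenyl on a carbon with a double bond to nitrogen. In words, 2,4-dichlorophenyl sits in place of 3,4-dihydroxyphenyl on a carbon with a double bond to nitrogen. Within the data shown here, only one measured step bears on this, a change at the same place: a 1.1-fold lower number from compound 1 to compound 2 (0.05 log units; within the scatter). Among the measured compounds shown here, with that single step as the guide, no change beyond the scatter is expected in this assay, though no measured compound yet carries 2,4-dichlorophenyl. The estimated step is a 1.0-fold lower number from compound 2 to compound 3 (0.01 log units; within the scatter). For compound 3 the expected value is 150000 nM, with an estimated range of 70000 nM to 300000 nM.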

Compound 3, half-maximal inhibitory concentration: 221000 nM
The estimate for compound 3 lay 1.5-fold (0.17 log units) below the measured number; the range from low to high includes it.
By their numbers in this assay, from the lowest: compounds 2, 1 and 3 (each within the scatter of the next).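

In this assay the exchange at this place, on a carbon with a double bond to nitrogen, gives a 1.4-fold higher number from compound 2 to compound 3 (0.16 log units; within the scatter) and the exchange from the other hydroxyl-bearing ring gives a 1.3-fold higher number from compound 1 to compound 3 (0.11 log units; within the scatter). This extends the earlier result to a group with no hydroxyl: 2,4-dichlorophenyl has 0 hydrogen-bond donors and 0 hydrogen-bond acceptors against 2 of each in 3,4-dihydroxyphenyl, yet all three compounds stand level within the scatter. No measurement bears on why the numbers stay level here. The compounds shown carry only chloro- and hydroxy-substituted phenyl groups at this place, so it remains open whether an amine, a carboxylic acid or a longer chain in that place would move the number beyond the scatter. On these data alone, whether any change elsewhere on the shared core would do so also remains open.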